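Amide nitrogen substituent and paw-edema inhibition in pyrazole carboxamides

This account rests on a few compounds, and the source may have more. Where it says the series, first, only, none or still open, it means among the compounds named here.

Measured compounds:
compound 1 `CCCCOc1cc(C(=O)NCCO)nn1-c1ccccc1` gives 61.2%
compound 2 `CCCCOc1cc(C(=O)NC(C)C)nn1-c1ccccc1` gives 15.8%

In a functional assay on the whole organism (strain Wistar) for inhibition, with Rattus norvegicus as the target, read by paw edema, with stated times of 30 min and 3 h, at a dose of 100 mg/kg by the oral route (on this read-out lower numbers stand for less inhibition and higher numbers for more inhibition at the one dose given (going by the name of the read-out)), compound 2 stands lowest of the two measured compounds, with compound 1 the nearest neighbour. For the measured compounds named here, the one measured step, a number 45.4 percentage points lower from compound 1 to compound 2 (beyond the scatter), is large and beyond the scatter. Compound 3 `CCCCOc1cc(C(=O)NCCCN(C)C)nn1-c1ccccc1` differs from compound 2 by 3-(dimethylamino)propyl in place of isopropyl on an amide-type nitrogen. Going by the values given here, no measured step carries this exact change, but the step from compound 1 to compound 2 showed that isopropyl on the amide nitrogen sits far below a heteroatom-bearing chain. Compound 3 is therefore expected to rise, with a number 24.2 percentage points higher from compound 2 to compound 3 (beyond the scatter), to an estimated 40% (range 15% to 65%).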

Compound 3, a percentage reported as inhibition, in the whole organism at one dose (the size of the read-out at that dose, not a potency): 29.8%
The estimate for compound 3 lay 10.2 percentage points above the measured number, and the stated range covers the measured number.
By their numbers in this assay, from the lowest: compound 2; then compound 3; then compound 1.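

In this assay, 3-(dimethylamino)propyl in place of isopropyl on the amide-type nitrogen gives a number 14 percentage points higher from compound 2 to compound 3 (beyond the scatter), while (dimethylamino)methyl in place of hydroxy on the chain gives a number 31.4 percentage points lower from compound 1 to compound 3 (beyond the scatter). A heteroatom-bearing chain therefore does not by itself reach the level of the 2-hydroxyethyl chain, and the dimethylamino chain stands between the other two. Nothing at hand explains this order. Open, from the compounds shown here alone, is whether chain length or the end group sets the difference: a 3-hydroxypropyl chain or a 2-(dimethylamino)ethyl chain would separate the two.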